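Imidazole to piperidine on the propyl chain

A few compounds are considered here, and "the series" means these few. Any claim that something is new, unique, unknown or untested is made for them only; others in the source may bear on it.

Measured in a functional assay on KB cells (Homo sapiens) for antiproliferative activity, read by MTT assay, with a stated time of 48 h; a higher number here means a weaker inhibitor, a lower number a stronger inhibitor:
compound 1 `Cn1cc(C2=C(c3nn(CCCN4CCCCC4)c4ncccc34)C(=O)N(c3ccccc3)C2=O)c2ccccc21`: 5600 nM
compound 2 `Cn1cc(C2=C(c3nn(CCCn4ccnc4)c4ncccc34)C(=O)NC2=O)c2ccccc21`: > 100000 nM

Compound 2 gives > 100000 nM in this assay, and this is a limit of the assay and not a number. Compound 2 therefore has no exact position in the series. Compound 3 `Cn1cc(C2=C(c3nn(CCCN4CCCCC4)c4ncccc34)C(=O)NC2=O)c2ccccc21` follows from compound 2 by one change, piperidin-1-yl in place of 1H-imidazol-1-yl on a saturated chain carbon, three bonds along the chain from an aromatic nitrogen. Within the data shown here, no measured pair isolates this change. Compound 1 also holds piperidin-1-yl and gives 5600 nM, but it differs from compound 3 elsewhere, so it is only a rough guide. On that basis, the expected step of an at least 6.6-fold lower number from compound 2 to compound 3 (0.82 log units; beyond the scatter) is towards stronger inhibition and beyond the scatter. For compound 3 the estimated value is 15000 nM, with an expected range of 3000 nM to 70000 nM.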

Compound 3, half-maximal inhibitory concentration: 98000 nM
Compound 3: middle estimate off by 6.5-fold (0.82 log units), on the low side, outside the stated range (above it).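

The change from 3-(1H-imidazol-1-yl)propyl to 3-(piperidin-1-yl)propyl reads as an at least 1.0-fold lower number from compound 2 to compound 3 (0.00 log units; that floor lies within the scatter), so in this assay no gain from it is shown. That step is only a floor because compound 2 carries a limit of the assay and not a number: the limit of > 100000 nM in this assay, at which 1 of the 3 values shown sits.

The larger difference lies at the other place, with hydrogen in place of phenyl on an amide-type nitrogen in a ring: an 18-fold higher number from compound 1 to compound 3 (1.24 log units; beyond the scatter), so of this piperidin-1-yl pair the phenyl-bearing member is the stronger inhibitor.

Open, as far as these compounds go, is whether phenyl on that nitrogen would give a step of similar size with 1H-imidazol-1-yl on the chain. Also open, from the compounds shown here alone, is where a dimethylamino group, a morpholin-4-yl ring or a shorter ethyl chain would fall, and whether a benzyl group on the amide-type nitrogen would match phenyl.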